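Swapping Trifluoromethyl for Methoxy on a Lactam Core

This account rests on a few compounds, and the source may have more. Where it says the series, first, only, none or still open, it means among the compounds named here.

Compound 1 `O=C1C=CCC(/C=C/c2ccc(C(F)(F)F)cc2)O1` and compound 2 `COc1ccc(/C=C/C2CC=CC(=O)O2)cc1` share one core and differ in a single group: methoxy in place of trifluoromethyl on an aromatic carbon In a functional assay on 786-0 cells (Homo sapiens) for inhibition, read by sulforhodamine B assay, with a stated time of 48 h (a lower number here means a stronger inhibitor of growth, a higher number a weaker inhibitor of growth), compound 1 gives 44.5 uM, while compound 2 gives 21.6 uM, which is a 2.1-fold lower number from compound 1 to compound 2 (0.31 log units; beyond the scatter). Compound 3 `O=C1C=CCC(/C=C/c2ccc(C(F)(F)F)cc2)N1` carries the trifluoromethyl group on a different core; the difference between the two cores is not broken down here. In this assay compound 3 gives 128 uM, the highest number of the three. Among the compounds with values here, compound 4 `COc1ccc(/C=C/C2CC=CC(=O)N2)cc1` arises from compound 3 by the same change: methoxy in place of trifluoromethyl on an aromatic carbon The expected step is a 2.1-fold lower number from compound 3 to compound 4 (0.33 log units; beyond the scatter), since the one earlier instance of this change gave a 2.1-fold lower number from compound 1 to compound 2 (0.31 log units; beyond the scatter). Compound 4 is therefore estimated at 60 uM, expected to fall between 30 uM and 120 uM.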

Compound 4, concentration for growth inhibition (reported as GI): > 1090 uM
Compound 4 was reported as a limit; the forecaster's own chance of this, stated with the estimate: 10%; middle value at least 18-fold (1.25 log units) away from the limit.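

In this assay the same swap gives an at least 8.5-fold higher number from compound 3 to compound 4 (0.93 log units; beyond the scatter), so a step seen on the core of compound 1 does not carry over to the core of compound 3: the same change on two cores in this assay, a 2.1-fold lower number (0.31 log units; beyond the scatter) from compound 1 to compound 2 and an at least 8.5-fold higher number (0.93 log units; beyond the scatter) from compound 3 to compound 4, at least 17-fold (1.24 log units) apart, beyond the scatter of two such steps

On these data alone, compound 4 is reported only as a limit of the assay, > 1090 uM, so the full size of this step stays unknown.

These two pairs show that the outcome of the swap differs between the two cores, but they do not show why, and they set no rule for any other core.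

The compounds shown leave open how a chlorine atom, an amine or a carboxylic acid in the same place would behave on each core. They also leave open whether any group other than methoxy would give a similar split between the two cores.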